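Sulfonamide series: aryl swap from compound 3 to compound 4

The source may hold more compounds than are shown below. What is called first, only, known or untested is meant among the compounds shown, and "the series" means these compounds.

Measured compounds, read in a functional assay on NCI-H1975 cells (Homo sapiens) for antiproliferative activity, read by MTT assay, with a stated time of 72 h; a lower number here means a stronger inhibitor, a higher number a weaker inhibitor:
compound 1 `COc1cc2ncnc(Nc3cccc(Cl)c3F)c2cc1OCCCCC(=O)Nc1ccc(S(N)(=O)=O)cc1` gives 6930 nM
compound 2 `NS(=O)(=O)c1ccc(NC(=S)Nc2ccc3ncnc(Nc4ccc(Cl)c(C(F)(F)F)c4)c3c2)cc1` gives 11800 nM
compound 3 `NS(=O)(=O)c1ccc(NC(=S)Nc2ccc3ncnc(Nc4cccc(Br)c4)c3c2)cc1` gives 11000 nM

Compound 3 stands second highest of the three numbers in this assay, nearest to compound 2 and furthest from compound 1, both gaps within the scatter. Compound 4 `Cc1ccc(Nc2ncnc3ccc(NC(=S)Nc4ccc(S(N)(=O)=O)cc4)cc23)cc1` differs from compound 3 by 4-methylphenyl in place of 3-bromophenyl on a nitrogen on an aromatic ring. Going by the values given here, the only measured step at this position is a 1.1-fold lower number from compound 2 to compound 3 (0.03 log units; within the scatter), which did not move the number beyond the scatter. Among the compounds with values here, no measured step compares a methyl-bearing ring with a halogen-bearing ring here, so the expectation rests on that single flat step. A step of a 1.3-fold higher number from compound 3 to compound 4 (0.10 log units; within the scatter) is therefore expected for compound 4, in practice none beyond the scatter. Compound 4 is estimated at 14000 nM, between 6000 nM and 35000 nM.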

Compound 4, half-maximal inhibitory concentration: 39400 nM
The estimate for compound 4 lay 2.8-fold (0.45 log units) below the measured number; measured number above the stated range.
By their numbers in this assay, from the lowest: compounds 1, 3 and 2 (each within the scatter of the next); then compound 4.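

In this assay, going by these compounds alone, the aryl group on this nitrogen proves not to be a silent position: 4-methylphenyl gives a clear change against both halogen-bearing rings (a 3.6-fold higher number from compound 3 to compound 4 (0.55 log units; beyond the scatter); a 3.3-fold higher number from compound 2 to compound 4 (0.52 log units; beyond the scatter)), whereas the one earlier step here stayed within the scatter. Among these three rings, 3-bromophenyl and 4-chloro-3-(trifluoromethyl)phenyl stay level, and only the ring without halogen stands apart, on the weaker side. No measurement at hand explains this shift.
Compound 4 alone carries methyl, and its substitution pattern also differs, so the two changes remain unseparated. On these data alone, how a methoxy group or an amine on this ring would read remains open.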